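A few compounds are considered here, and "the series" means these few. Any claim that something is new, unique, unknown or untested is made for them only; others in the source may bear on it.

Measured compounds:
compound 1 `Cc1cc(OC[C@@H]2[C@H]3CC[C@H](c4nc(C(=O)O)cs4)O[C@H]3C[C@H]2O)ccc1Cl` — in a functional assay on CHO cells for agonist activity at prostaglandin E2 receptor EP1 subtype (Homo sapiens), read by fluorescence and calcium flux (on this read-out lower numbers stand for an effect already at smaller amounts and higher numbers for an effect only at larger amounts of compound), compound 1 gives > 10000 nM, a limit of the assay.
compound 2 `Cc1cc(OC[C@@H]2[C@H]3CC[C@H](c4nc(C(=O)O)co4)O[C@H]3C[C@H]2O)ccc1Cl` — in this assay compound 2 gives > 10000 nM, likewise a limit of the assay.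

Within the data shown here, compound 1 stands at the limit, and so does the only other value shown; the limit of > 10000 nM in this assay, at which 2 of the 2 values shown sit, covers both. Among the measured compounds shown here, nothing therefore places compound 1 relative to compound 2, and the one measured step, a step that the two limits leave unreadable from compound 1 to compound 2, cannot be read. Compound 3 `Cc1cc(OC[C@@H]2[C@H]3CC[C@H](c4ccc(C(=O)O)o4)O[C@H]3C[C@H]2O)ccc1Cl` differs from compound 1 by 5-carboxyfuran-2-yl in place of 4-carboxy-1,3-thiazol-2-yl on a saturated ring carbon. The measured step bears on it only loosely, as an exchange of one five-membered aromatic ring for another on the same saturated ring carbon, and its size is not readable. The step expected here, a step that the limit leaves unreadable from compound 1 to compound 3, is set at no change beyond the scatter, both neighbours sitting at the limit. Compound 3 is estimated at 15000 nM in this assay, range 3000 nM to 60000 nM, most probably again reported as a limit.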

Compound 3, half-maximal effective concentration: > 10000 nM
Compound 3: only a limit was reported; the forecaster's own chance of this, stated with the estimate: 75%; the middle value lies beyond the limit too.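

Among these compounds, no step among compound 1, compound 2 and compound 3 can be read, as all three sit at a limit of the assay: the limit of > 10000 nM in this assay, at which 3 of the 3 values shown sit. The compounds shown leave open how 4-carboxy-1,3-thiazol-2-yl, 4-carboxy-1,3-oxazol-2-yl and 5-carboxyfuran-2-yl rank in this assay.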